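Changing the benzyl aryl group: compound 3 to compound 4

The source may hold more compounds than are shown below. What is called first, only, known or untested is meant among the compounds shown, and "the series" means these compounds.

Of the compounds shown here, three have been measured in a functional assay on MCF7 cells (Homo sapiens) for inhibition, read by MTT assay, with a stated time of 72 h; a lower number here means a stronger inhibitor of growth, a higher number a weaker inhibitor of growth: compound 1 `O=S(=O)(NCCCNCc1ccc(Cl)c(Cl)c1)c1cc(C(F)(F)F)cc(C(F)(F)F)c1` with 2400 nM, compound 2 `O=S(=O)(NCCCNCc1ccc(C(F)(F)F)cc1)c1cc(C(F)(F)F)cc(C(F)(F)F)c1` with 1400 nM, and compound 3 `O=S(=O)(NCCCNCc1ccc(Br)cc1)c1cc(C(F)(F)F)cc(C(F)(F)F)c1` with 1900 nM.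

Compound 3 sits second highest of the three numbers; its nearest neighbour is compound 1, with a 1.3-fold lower number from compound 1 to compound 3 (0.10 log units; within the scatter), and its furthest is compound 2, with a 1.4-fold higher number from compound 2 to compound 3 (0.13 log units; within the scatter). Compound 4 `O=S(=O)(NCCCNCc1cccc(Cl)c1)c1cc(C(F)(F)F)cc(C(F)(F)F)c1` differs from compound 3 by 3-chlorophenyl in place of 4-bromophenyl on a saturated chain carbon bound to an amine nitrogen. Every measured step in this set alters that same aryl group, and a 1.7-fold lower number from compound 1 to compound 2 (0.23 log units; within the scatter), a 1.3-fold lower number from compound 1 to compound 3 (0.10 log units; within the scatter) and a 1.4-fold higher number from compound 2 to compound 3 (0.13 log units; within the scatter) all stay within the scatter. A further change at this position is therefore expected to give no step beyond the scatter in this assay. Compound 4 is estimated at 2000 nM, within a range from 900 nM to 4500 nM. That estimate amounts to a 1.1-fold higher number from compound 3 to compound 4 (0.02 log units; within the scatter).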

Compound 4, concentration for 50% growth inhibition: 2600 nM
Estimate against measurement, compound 4: 1.3-fold (0.11 log units) below; measured number inside the range.
By their numbers in this assay, from the lowest: compounds 2, 3, 1 and 4 (each within the scatter of the next).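

In this assay, 3-chlorophenyl on this saturated chain carbon stays within the scatter of 4-bromophenyl (a 1.4-fold higher number from compound 3 to compound 4 (0.14 log units; within the scatter)) and of 4-(trifluoromethyl)phenyl (a 1.9-fold higher number from compound 2 to compound 4 (0.27 log units; within the scatter)). Hydrogen in place of chloro on an aromatic carbon also leaves the number within the scatter (a 1.1-fold higher number from compound 1 to compound 4 (0.03 log units; within the scatter)), so a single chloro can go from the aryl group with no readable step. Nothing measured here offers an explanation for these results.

As far as these compounds go, whether a pyridine ring or a cyclohexyl group at this place would stay within the scatter remains open. So does the effect of a longer chain in the shared core.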